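A few compounds are considered here, and "the series" means these few. Any claim that something is new, unique, unknown or untested is made for them only; others in the source may bear on it.

Working notes on the series.

Of the compounds shown here, three have been measured in a physicochemical assay for solubility, read by LC-MS, in phosphate buffer, with a stated time of 24 h, at pH 7.4; on this read-out higher numbers stand for higher solubility and lower numbers for lower solubility. Compound 1 `Cc1nccn1-c1cnc(NCc2c(F)ccc3c2CCO3)c2cn[nH]c(=O)c12` gives 7000 nM. For the measured compounds named here, compound 2 `CNC(=O)c1ccc(-c2cnc(NCc3c(F)ccc4c3CCO4)c3cn[nH]c(=O)c23)c(C)n1` gives 19000 nM, and the only single-point step in the set is a 2.7-fold higher number from compound 1 to compound 2 (0.43 log units; beyond the scatter), which replaces 2-methyl-1H-imidazol-1-yl with 2-methyl-6-(methylcarbamoyl)pyridin-3-yl on an aromatic carbon. Compound 3 `Fc1ccc2c(c1CNc1ncc(Oc3ccccc3)c3nncn13)CCO2` gives 8000 nM, second of the three numbers: its value and that of compound 1 sit within the scatter of each other, while compound 2 stands beyond the scatter above it.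

Compound 4 `Fc1ccc2c(c1CNc1ncc(Nc3ccccc3)c3nncn13)CCO2` differs from compound 3 in one place: anilino in place of phenoxy on an aromatic carbon. The change sits on an aromatic carbon of a six-membered aromatic ring with 2 nitrogen, part of a fused or bridged system of two rings, ortho to a fused ring. Going by the values given here, no measured step in this assay involves a phenoxy-to-anilino swap; the step from compound 1 to compound 2 concerns a different group on a different core and does not bear on it. Among the compounds with values here, with no comparable step available, the expectation for compound 4 is a step of about no change at the digits printed from compound 3 to compound 4 (within the scatter), that is, nothing beyond the scatter in either direction. Compound 4 is therefore estimated at 8000 nM, with a range of 3000 nM to 20000 nM.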

Compound 4, solubility: 3000 nM
For compound 4 the middle estimate is 2.7-fold (0.43 log units) above the measured one; low and high end bracket the measured number.
By their numbers in this assay, from the lowest: compound 4; then compounds 1 and 3 (each within the scatter of the next); then compound 2.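

In this assay, anilino in place of phenoxy gives a 2.7-fold lower number from compound 3 to compound 4 (0.43 log units; beyond the scatter), so a single-atom exchange at this position, on an aromatic carbon of the shared core, moves the number beyond the scatter. The two groups match in heavy-atom count and in their six-membered aromatic ring of carbon only; as counted, they differ in the linking atom, nitrogen against oxygen, and in anilino carrying 1 hydrogen-bond donor where phenoxy has 0. No measurement here connects either difference to the step.

Going by these compounds, whether the step comes from the hydrogen on the anilino nitrogen remains open, and N-methylanilino at this position would separate that hydrogen from the nitrogen itself. Also open, on these data alone, is whether the same swap gives a step of similar size on the core of compound 1.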